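Swapping the linked group on the long-chain compound

The compounds below may be only part of what the source reports. "The series", "measured", "known", "first", "only" and "open" are said of these compounds alone.

Within the data shown here, in a functional assay on DU-145 cells (Homo sapiens) for cytotoxicity, read by MTT assay, with a stated time of 24 h (on this read-out higher numbers stand for weaker inhibition and lower numbers for stronger inhibition), two compounds have numbers so far. Compound 1 (`Nc1nc(OCc2cn(-c3n[nH]c4nc(C(F)(F)F)ccc34)nn2)cc(C(F)(F)F)n1`) gives 28900 nM, and compound 2 (`Nc1nc(C(F)(F)F)cc(=O)n1Cc1cn(-c2nn(CCC(F)(F)C(F)(F)C(F)(F)C(F)(F)C(F)(F)C(F)(F)C(F)(F)C(F)(F)F)c3nc(C(F)(F)F)ccc23)nn1`) gives 88800 nM. Compound 2 therefore holds the higher of the two numbers, and its gap to compound 1 lies beyond the scatter.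

Compound 3 (`Nc1nc(OCc2cn(-c3nn(CCC(F)(F)C(F)(F)C(F)(F)C(F)(F)C(F)(F)C(F)(F)C(F)(F)C(F)(F)F)c4nc(C(F)(F)F)ccc34)nn2)cc(C(F)(F)F)n1`) has the same atoms as compound 2, joined differently: a group of 12 heavy atoms (5 carbon, 3 nitrogen, 1 oxygen, 3 fluorine; one six-membered aromatic ring with 2 hetero atoms) in place of a group of 12 heavy atoms (5 carbon, 3 nitrogen, 1 oxygen, 3 fluorine; one six-membered aromatic ring with 2 hetero atoms), on a saturated chain carbon bound to an aromatic carbon. The entering group is (2-amino-6-(trifluoromethyl)pyrimidin-4-yl)oxy. Among the measured compounds shown here, no measured pair isolates this change, so the expectation rests on thin evidence. Compound 1 carries that same group and gives 28900 nM, so a small move toward lower numbers is expected in this assay, possibly not beyond the scatter. The estimated size is a 1.6-fold lower number from compound 2 to compound 3 (0.21 log units; within the scatter). Compound 3 is expected at 55000 nM, with an estimated range of 22000 nM to 130000 nM.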

Compound 3, half-maximal inhibitory concentration: 37700 nM
For compound 3 the middle estimate is 1.5-fold (0.16 log units) above the measured one; measured number inside the range.
By their numbers in this assay, from the lowest: compounds 1 and 3 (each within the scatter of the next); then compound 2.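

In this assay, with the long chain kept, exchanging the leaving group for (2-amino-6-(trifluoromethyl)pyrimidin-4-yl)oxy on a saturated chain carbon bound to an aromatic carbon gives a 2.4-fold lower number from compound 2 to compound 3 (0.37 log units; beyond the scatter), a modest step. The two compounds have the same atoms, joined differently, so how this group is joined already matters at this position, while compound 3 at 37700 nM stays within the scatter of compound 1 at 28900 nM, which lacks the long chain. Nothing available on the compounds accounts for this step.

Open, from the compounds shown here alone, is whether an amine in place of the (2-amino-6-(trifluoromethyl)pyrimidin-4-yl)oxy group, on the same saturated chain carbon, would keep the number near that of compound 3. Also open, going by these compounds, is whether a longer chain would leave the number within the scatter of compound 3.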